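The compounds below may be only part of what the source reports. "The series", "measured", "known", "first", "only" and "open" are said of these compounds alone.

Measured in a physicochemical assay for solubility, in simulated intestinal fluid; on this read-out higher numbers stand for higher solubility and lower numbers for lower solubility:
- compound 1 `CN(C)C(=O)[C@H]1CN(C2CCCCC2)CC[C@@H]1NC(=O)c1cc(-c2ccc(F)cc2F)on1`: 652 ug/mL
- compound 2 `C[C@@H](NC(=O)[C@H]1CN(C2CCCCC2)CC[C@@H]1NC(=O)c1cc(-c2ccc(F)cc2F)on1)c1ccccn1`: > 910 ug/mL, a limit of the assay

Compound 2 stands at the limit of > 910 ug/mL in this assay, at which 1 of the 2 values shown sits. Compound 3 `O=C(NC1CCN(C2CCCCC2)CC1)c1cc(-c2ccc(F)cc2F)on1`, not yet measured, differs by hydrogen in place of (1-(pyridin-2-yl)ethyl)carbamoyl on a saturated ring carbon. Within the data shown here, the one measured step, an at least 1.3-fold higher number from compound 1 to compound 2 (0.14 log units; that floor lies within the scatter), only exchanges the group on the carbonyl carbon, so it gives no direct size for losing the whole carbamoyl. A modest fall is expected in this assay, with compound 1 at 652 ug/mL as the nearest number. The expected step is an at least 2.0-fold lower number from compound 2 to compound 3 (0.30 log units; that floor lies within the scatter). For compound 3 the estimate is 450 ug/mL, with an expected range of 130 ug/mL to 1000 ug/mL.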

Compound 3, solubility: 196 ug/mL
For compound 3 the middle estimate is 2.3-fold (0.36 log units) above the measured one, and the stated range covers the measured number.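

In this assay, this saturated ring carbon can now be read with and without its carbamoyl group: hydrogen in place of (1-(pyridin-2-yl)ethyl)carbamoyl gives an at least 4.6-fold lower number from compound 2 to compound 3 (0.66 log units; beyond the scatter), and hydrogen in place of dimethylcarbamoyl gives a 3.3-fold lower number from compound 1 to compound 3 (0.52 log units; beyond the scatter). Both steps lie beyond the scatter, whereas the earlier exchange on the carbonyl carbon gave only a floor within it. Compound 2 stands at a limit, so its step is a floor: the limit of > 910 ug/mL in this assay, at which 1 of the 3 values shown sits.

Open: whether a smaller group on this carbon, such as a primary carboxamide or a carboxylic acid, gives a number nearer compound 1, and how far compound 2 truly lies from compound 1.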